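The source may hold more compounds than are shown below. What is called first, only, known or untested is meant among the compounds shown, and "the series" means these compounds.

Compound 1 `COc1ccc(-c2cc(/C=C/C(=O)c3ccc(N)cc3)[nH]n2)cc1`: 105%
Compound 2 `COc1cc(-c2cc(/C=C/C(=O)c3ccc(N)cc3)[nH]n2)cc(OC)c1OC`: 97%

Of the compounds shown here, two have been tested in a functional assay on HCT-116 cells (Homo sapiens) for cytotoxicity, read by sulforhodamine B assay, with a stated time of 48 h, tested at 0.1 uM; on this read-out higher numbers stand for a weaker effect at the one concentration tested and lower numbers for a stronger effect. Compound 1 gives 105% and compound 2 gives 97%; compound 2 stands beside compound 1, the two numbers lying within the scatter of each other, so neither can be set apart. Compound 3 `COc1ccc(C(=O)/C=C/c2cc(-c3cc(OC)c(OC)c(OC)c3)n[nH]2)cc1` has not yet been measured. It differs from compound 2 in one place: methoxy in place of amino on an aromatic carbon. For the measured compounds named here, no step between measured compounds covers this change, so nothing here points a direction. With both measured numbers near the top of the scale, the step of a number 3 percentage points higher from compound 2 to compound 3 (within the scatter) is expected to stay within the scatter. Compound 3 is estimated at 100%, between 85% and 115%.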

Compound 3, a percentage reported as activity, at one concentration (the size of the read-out at that concentration, not a potency): 102%
The estimate for compound 3 lay 2 percentage points below the measured number; the measured number falls inside the stated range.
By their numbers in this assay, from the lowest: compounds 2, 3 and 1 (each within the scatter of the next).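

In this assay, putting methoxy in place of amino on an aromatic carbon, para to a large group, gives a number 5 percentage points higher from compound 2 to compound 3 (within the scatter). Turning 4-aminophenyl into 4-methoxyphenyl therefore leaves the read-out at this position unchanged, even though the amino hydrogen-bond donor is gone. No measured data bear on why this is so. From the compounds shown here alone, whether a hydroxyl or a carboxylic acid on this carbon would shift the number remains open. So does how these compounds compare at any other concentration, since only one is shown.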